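Replacing the amine side chain with chloro on the core

This account rests on a few compounds, and the source may have more. Where it says the series, first, only, none or still open, it means among the compounds named here.

Measured compounds:
compound 1 `CCCCOc1ccc2c(Cl)ccnc2c1` with 2740 nM
compound 2 `CCCCCCOc1ccc2c(Cl)ccnc2c1` with 2440 nM
compound 3 `C=CCOc1ccc2c(NCCCN(C)C)ccnc2c1` with 2100 nM

In a functional assay on HCT-116 cells (Homo sapiens) for cytotoxicity, read by MTT assay, with a stated time of 48 h (on this read-out lower numbers stand for stronger inhibition and higher numbers for weaker inhibition), compound 3 gives 2100 nM, the lowest of the three numbers, though its distance to compound 2 and to compound 1 lies within the scatter on both sides, so no order can be read from them. Compound 4 `C=CCOc1ccc2c(Cl)ccnc2c1` has not yet been measured. It differs from compound 3 by chloro in place of (3-(dimethylamino)propyl)amino on an aromatic carbon. For the measured compounds named here, the one measured step, a 1.1-fold lower number from compound 1 to compound 2 (0.05 log units; within the scatter), concerns a change on the alkoxy chain and not the aromatic carbon where the present change sits, so no measured step bears directly on it. What can be said is that compound 1, which carries the chloro group at that position, gives 2740 nM, within the scatter of compound 3. Compound 2, which carries the chloro group at that position too, gives 2440 nM, also within the scatter of compound 3. The author therefore expects for compound 4 a step of a 1.2-fold higher number from compound 3 to compound 4 (0.09 log units; within the scatter), that is, no change beyond the scatter in this assay. The estimate for compound 4 is 2600 nM, with a range from 1300 nM to 5500 nM.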

Compound 4, half-maximal inhibitory concentration: 2570 nM
Beside the measured number, compound 4's estimate is 1.0-fold (0.01 log units) above it, and the stated range covers the measured number.
By their numbers in this assay, from the lowest: compounds 3, 2, 4 and 1 (each within the scatter of the next).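

In this assay, for the compounds shown here, the exchange of (3-(dimethylamino)propyl)amino for chloro, on the aromatic carbon opposite the ring nitrogen and with the rest of the molecule unchanged, gives a 1.2-fold higher number from compound 3 to compound 4 (0.09 log units; within the scatter) and so provides the first direct reading at this position. Removing the whole side chain, with its two nitrogens and its hydrogen-bond donor, therefore leaves the number within the scatter for this pair. Compound 4 also connects the chloro compounds through their alkoxy chains, with vinyl in place of pentyl giving a 1.1-fold higher number from compound 2 to compound 4 (0.02 log units; within the scatter) and vinyl in place of propyl giving a 1.1-fold lower number from compound 1 to compound 4 (0.03 log units; within the scatter) so that neither chain exchange moves the number beyond the scatter either.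

The compounds shown leave open whether a different group on that aromatic carbon, such as a morpholine, a piperazine or a longer aminoalkyl chain, would give a step beyond the scatter. They also leave open whether the (3-(dimethylamino)propyl)amino group would give the same result on the shared core with a butoxy or hexyloxy chain, and nothing available explains why the exchange of chloro for the amine side chain stays within the scatter.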